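A few compounds are considered here, and "the series" means these few. Any claim that something is new, unique, unknown or untested is made for them only; others in the source may bear on it.

Measured so far:
- Compound 1, `NC(=O)N(O)CC1=Cc2cc(OCc3ccc(C(F)(F)F)cc3)ccc2OC1`: 490 nM
- Compound 2, `NC(=O)N(O)CC1=Cc2cc(OCC3CCCCC3)ccc2OC1`: 1390 nM
- Compound 3, `CCCCNC(=O)N(O)CC1=Cc2cc(Oc3ccccc3)ccc2OC1`: 69 nM

All three compounds were measured in an assay (Cavia porcellus) for inhibition of Polyunsaturated fatty acid 5-lipoxygenase (Homo sapiens); on this read-out lower numbers stand for stronger inhibition and higher numbers for weaker inhibition. Compound 3, at 69 nM, has the lowest of the three numbers, and its gaps to compound 1 and to compound 2 both lie beyond the usual scatter, so it stands as the strongest inhibitor among the measured set. Compound 4, `CCOC(=O)CNC(=O)N(O)CC1=Cc2cc(Oc3ccccc3)ccc2OC1`, has not yet been measured. It differs from compound 3 in one place: ethoxycarbonyl in place of propyl on a saturated chain carbon bound to an amide-type nitrogen. The hydroxyurea and the shared core are unchanged. Going by the values given here, no measured pair in this set shows the effect of such a change, so the expectation rests on the unchanged parts alone. A modest weakening, close to the scatter, is expected for a 2.2-fold higher number from compound 3 to compound 4 (0.34 log units; beyond the scatter). For compound 4, the estimate in this assay is 150 nM, with a range from 40 nM to 600 nM.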

Compound 4, half-maximal inhibitory concentration: 74 nM
For compound 4 the middle estimate is 2.0-fold (0.31 log units) above the measured one; the measured number falls inside the stated range.
By their numbers in this assay, from the lowest: compounds 3 and 4 (each within the scatter of the next); then compound 1; then compound 2.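

In this assay, ethoxycarbonyl in place of propyl on a saturated chain carbon bound to an amide-type nitrogen gives a 1.1-fold higher number from compound 3 to compound 4 (0.03 log units; within the scatter) and so leaves the two compounds indistinguishable on this read-out. The entering group has 5 heavy atoms and 2 hydrogen-bond acceptors against 3 and 0 for propyl, so at this place in this pair, a larger group carrying acceptors still gives a number within the scatter of the propyl compound. Nothing measured here explains why the two numbers match.

The compounds shown leave open whether a carboxylic acid in place of the ethoxycarbonyl, or an amine on the same chain, would also match. They also leave open whether the same swap would give a matching number alongside the other side chains of compound 1 or compound 2.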